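Swapping Bromo for Hydroxy on the Aryl Hydrazone

The compounds below may be only part of what the source reports. "The series", "measured", "known", "first", "only" and "open" are said of these compounds alone.

Compound 1 `C/C(=N\NC(=O)COc1cccc2ccccc12)c1cccc([N+](=O)[O-])c1` gives 10.5 ug/mL
Compound 2 `C/C(=N\NC(=O)COc1cccc2ccccc12)c1ccc(Br)cc1` gives 15.3 ug/mL

In an ADME assay on HEL cells (Homo sapiens) for cytotoxicity (on this read-out higher numbers stand for lower toxicity in this test and lower numbers for higher toxicity in this test), compound 2 gives 15.3 ug/mL and lies within the scatter of compound 1, so neither compound stands apart. The next compound is compound 3 `C/C(=N\NC(=O)COc1cccc2ccccc12)c1ccc(O)cc1` and its change from compound 2 is hydroxy in place of bromo on an aromatic carbon with hydroxy in place of bromo on an aromatic carbon. Among the measured compounds shown here, only one measured step bears on this, and only loosely: a 1.5-fold higher number from compound 1 to compound 2 (0.16 log units; within the scatter) for 4-bromophenyl in place of 3-nitrophenyl. For the measured compounds named here, that single step stayed within the scatter, yet no measured compound carries hydroxy, so the range must stay wide. The estimated move is a 1.0-fold lower number from compound 2 to compound 3 (0.01 log units; within the scatter) and no step beyond the scatter is expected in this assay for this change. For compound 3 the expected value is 15 ug/mL within an estimated range from 7 ug/mL to 35 ug/mL for now.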

Compound 3, half-maximal cytotoxic concentration in the HEL assay: 11.1 ug/mL
For compound 3 the middle estimate is 1.4-fold (0.13 log units) above the measured one, within the range that was stated.
By their numbers in the HEL assay, from the lowest: compounds 1, 3 and 2 (each within the scatter of the next).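

At this spot, para to a large group, the first polar swap changes little: in the HEL assay hydroxy in place of bromo gives a 1.4-fold lower number from compound 2 to compound 3 (0.14 log units; within the scatter), and in the HEL assay 4-hydroxyphenyl in place of 3-nitrophenyl gives a 1.1-fold higher number from compound 1 to compound 3 (0.02 log units; within the scatter). A group with a hydrogen-bond donor is therefore tolerated here without a step beyond the scatter, and the three aryl groups cannot be told apart on this read-out. In a physicochemical assay for lipophilicity, measured as octanol-water partition (on this read-out higher numbers stand for higher lipophilicity and lower numbers for lower lipophilicity), compound 2 gives 3.61 and compound 3 gives 4.44. The read-out in the HEL assay stayed within the scatter even across a clear shift in the physicochemical assay: the measured partition coefficient of compound 2, 3.61, and of compound 3, 4.44, a number 0.83 log units higher (beyond the scatter)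

The compounds shown leave open whether an amine or a carboxylic acid on this aromatic carbon would also stay within the scatter in the HEL assay. They also leave open whether any change to the shared core, away from this aryl group, would move the number beyond it.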